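A few compounds are considered here, and "the series" means these few. Any claim that something is new, unique, unknown or untested is made for them only; others in the source may bear on it.

Measured so far:
compound 1 `N#Cc1cccc(-c2ccc(CN(CC(=O)Nc3cc(Cl)cc(Cl)c3)C(=O)CN3CCCC3)cc2)c1` — > 3000 nM
compound 2 `C[C@H](c1ccc(-c2cccc(C#N)c2)cc1)N(CC(=O)Nc1cc(Cl)cc(Cl)c1)C(=O)CCN1CC[C@H](O)C1` — > 3000 nM

In a functional assay for antagonist activity at melanin-concentrating hormone receptor 2 (Homo sapiens) (on this read-out higher numbers stand for weaker inhibition and lower numbers for stronger inhibition), compound 1 gives > 3000 nM, which is a limit of the assay and not a number. In this assay compound 2 gives > 3000 nM, also a limit. Within the data shown here, compound 2 therefore stands nowhere in particular on the scale: it sits at the limit of > 3000 nM in this assay, at which 2 of the 2 values shown sit, so no ranking of the two measured compounds is possible, and no step between them can be counted.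

Compound 3 `C[C@@H](c1ccc(-c2cccc(C#N)c2)cc1)N(CC(=O)Nc1cc(Cl)cc(Cl)c1)C(=O)CCN1CC[C@H](O)C1` is the next member. Its relation to compound 2 is the two compounds have the same atoms and bonds and differ only in configuration as drawn: 1 of 2 stereo elements differ; a stereocentre at a saturated chain carbon is drawn R in compound 2 and S in compound 3. Among the measured compounds shown here, no measured pair shows what a change of configuration alone does in this assay, so the size and direction of the step are open. The expectation is guarded: since compound 2 shows only a limit, the most likely outcome for compound 3 is again a limit, with a real chance that the other configuration reads as a number. The expected step is a number no higher from compound 2 to compound 3 (the limit leaves the size open). For compound 3 the estimate is 3000 nM, with a range from 300 nM to 10000 nM.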

Compound 3, inhibition constant: > 3000 nM
Compound 3 ended at the assay's limit; the forecaster's own chance of this, stated with the estimate: 60%; the middle value lies on the limit itself.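

No step can be read between compound 2 and compound 3 in this assay, as both values are limits of the assay and not numbers: the limit of > 3000 nM in this assay, at which 3 of the 3 values shown sit.

The compounds shown leave open what the change of configuration at the saturated chain carbon does to inhibition, and how the three compounds rank against one another.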